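The source may report more compounds than this note shows. Statements on the series, on what has been measured and on what is new or still open speak of the compounds shown alone.

Compound 1 `NC1=NC2(CCOCC2)N(OCCCOc2ccccc2)C(N)=N1`: 1080 nM
Compound 2 `NC1=NC2(CCSCC2)N(OCCCOc2cccc(Cl)c2)C(N)=N1`: 60 nM

For the measured compounds named here, in a functional assay on A549 cells (Homo sapiens) for antiproliferative activity, read by MTT assay, with a stated time of 72 h (a higher number here means a weaker inhibitor, a lower number a stronger inhibitor), compound 1 gives 1080 nM as the higher of the two numbers measured so far. Compound 2 reads 60 nM and so lies lower, by a gap beyond the usual scatter. Going by the values given here, no two measured compounds differ in one place only, so no single change has yet been sized directly.

Compound 3 `NC1=NC2(CCOCC2)N(OCCCOc2ccc(Cl)cc2Cl)C(N)=N1` has not been measured. It departs from compound 1 by one change, 2,4-dichlorophenyl in place of phenyl on an oxygen on a saturated carbon, counted as 2,4-dichlorophenyl in place of phenyl on an oxygen on a saturated carbon with nothing else altered.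

The value of compound 2 at 60 nM shows only that lower numbers are reachable among these compounds, so the evidence is thin. Even so, a moderate step to a lower number is expected in this assay and it probably lies beyond the scatter. The estimate amounts to an expected 3.6-fold lower number from compound 1 to compound 3 (0.56 log units; beyond the scatter) and remains uncertain. For compound 3 the estimated value is 300 nM with 80 nM to 1000 nM as the expected range.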

Compound 3, half-maximal inhibitory concentration: 70 nM
For compound 3 the middle estimate is 4.3-fold (0.63 log units) above the measured one; measured number outside the range, below it.
By their numbers in this assay, from the lowest: compounds 2 and 3 (each within the scatter of the next); then compound 1.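

In this assay, putting 2,4-dichlorophenyl in place of phenyl on an oxygen on a saturated carbon gives a 15-fold lower number from compound 1 to compound 3 (1.19 log units; beyond the scatter), a large step and the first single change among these compounds whose size can be read directly. With the rest of compound 1 held fixed, this place is therefore shown to be far from indifferent to the group it carries, something the earlier pair could not show because its members differ in more than one place. No measurement at hand accounts for the step, and it remains a bare observation of size.

The step covers both chlorine atoms at once, leaving open how much of it a single chlorine on the phenyl ring would give, and whether the two atoms contribute equally. Also open, going by these compounds, is whether other groups on that ring, such as a fluorine, a methoxy or a trifluoromethyl, would move the number as far, and whether the same change would hold with a shorter or longer chain in place of the present one.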